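The source may hold more compounds than are shown below. What is called first, only, known or untested is meant among the compounds shown, and "the series" means these compounds.

The series shares one core, seen in compound 1 `O=C(Nc1cccc(Cl)c1)Nc1cccc(CNc2nccnc2Cl)c1` and compound 2 `CS(=O)(=O)c1ccc(NC(=O)Nc2cccc(CNc3nccnc3Cl)c2)cc1`, and both have been run in a functional assay on HepG2 cells (Homo sapiens) for antiproliferative activity, read by MTT assay, with a stated time of 48 h; on this read-out lower numbers stand for stronger inhibition and higher numbers for weaker inhibition. In this assay compound 1 gives 9140 nM, the lower of the two numbers recorded, and compound 2 gives 15100 nM; the gap between them lies within the scatter, so the two read as equivalent and neither is called the more potent. For the measured compounds named here, no step between measured compounds that differ in a single place is available, so the only guide to a new member is the structural change itself.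

Compound 3 `O=C(Nc1cccc(CNc2nccnc2Cl)c1)Nc1ccccc1Cl` differs from compound 1 in one place: 2-chlorophenyl in place of 3-chlorophenyl on an amide-type nitrogen. The ring on that amide-type nitrogen is the same kind of ring carrying the same chlorine, only differently placed. With no measured comparison of this kind in the set, the expected step is a 1.1-fold higher number from compound 1 to compound 3 (0.04 log units; within the scatter), no more than the scatter, in either direction. Compound 3 is therefore expected to give about 10000 nM in this assay, within a range of 4000 nM to 25000 nM.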

Compound 3, half-maximal inhibitory concentration: 8560 nM
Compound 3: the middle estimate sits 1.2-fold (0.07 log units) above what was measured; the measured number falls inside the stated range.
By their numbers in this assay, from the lowest: compounds 3, 1 and 2 (each within the scatter of the next).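

In this assay, 2-chlorophenyl in place of 3-chlorophenyl on the amide-type nitrogen gives a 1.1-fold lower number from compound 1 to compound 3 (0.03 log units; within the scatter), so compound 1 and compound 3 read as equivalent. For the compounds shown here, this is the first comparison between two compounds that differ in a single place, and it replaces the earlier reliance on the structural change alone with a measured step. At this position, for this one exchange between two chlorophenyl groups with the same atoms joined differently, the assay does not separate the pair, although a single step says nothing about how other changes at the same place would behave; no supporting measurement is available that bears on this result.

The compounds shown leave open whether this position responds to anything other than a chlorophenyl group, for instance a phenyl ring carrying an amine or a carboxylic acid, or a longer alkyl chain in place of the ring, and whether any such change would give a step beyond the scatter. They also leave open how changes elsewhere on the shared core would register, since that part is identical in compound 1 and compound 3.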